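Thiourea benzamide series: pyridyl exchange from compound 2

The source may hold more compounds than are shown below. What is called first, only, known or untested is meant among the compounds shown, and "the series" means these compounds.

Three compounds of this series have a number in a functional assay on HCT-116 cells (Homo sapiens) for cytotoxicity, read by MTT assay, with a stated time of 72 h; a lower number here means a stronger inhibitor, a higher number a weaker inhibitor. Compound 1 `Nc1ccccc1NC(=O)c1ccc(NC(=O)NCc2ccc(Cl)nc2)cc1` gives 5200 nM. Compound 2 `Cc1ccc(CNC(=S)Nc2ccc(C(=O)Nc3ccccc3N)cc2)cn1` gives 11000 nM. Compound 3 `Nc1ccccc1NC(=O)c1ccc(CNC(=O)c2cc3cccnc3[nH]2)cc1` gives 10000 nM. Compound 2 stands highest of the three numbers; its gap to compound 3 lies within the scatter, so the two cannot be ordered, while its gap to compound 1 lies beyond the scatter, compound 1 showing the lower number. Compound 1 and compound 2 differ in more than one place, so no single step can be read from that pair.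

Compound 4 `Nc1ccccc1NC(=O)c1ccc(NC(=S)NCc2cncc(F)c2)cc1` has not yet been measured in this assay. It differs from compound 2 in one place: 5-fluoropyridin-3-yl in place of 6-methylpyridin-3-yl on a saturated chain carbon bound to an amide-type nitrogen. The thiourea linker, the saturated chain carbon bound to the amide-type nitrogen and the remainder of the core are unchanged. Among the compounds with values here, no measured pair isolates this exchange, so the data give no direct guide to its size. With the rest of the molecule held fixed, the step from compound 2 to compound 4 is expected to stay within the scatter, in either direction, and the estimate is a 1.2-fold lower number from compound 2 to compound 4 (0.09 log units; within the scatter). Compound 4 is therefore expected to give about 9000 nM in this assay, with a range from 3500 nM to 25000 nM.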

Compound 4, half-maximal inhibitory concentration: 15000 nM
Compound 4: the middle estimate sits 1.7-fold (0.22 log units) below what was measured, and the stated range covers the measured number.
By their numbers in this assay, from the lowest: compounds 1, 3, 2 and 4 (each within the scatter of the next, the first and the last beyond it).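

In this assay, the series now has its first step that differs in one place: 5-fluoropyridin-3-yl in place of 6-methylpyridin-3-yl on a saturated chain carbon bound to an amide-type nitrogen gives a 1.4-fold higher number from compound 2 to compound 4 (0.13 log units; within the scatter). With the thiourea linker and the remainder of the core held fixed, this pair therefore does not separate the two pyridyl groups, and the position accepts the exchange of one for the other without a readable shift in the number. No measurement at hand bears on this result, so nothing can be said about what lies behind it.

The compounds shown leave open whether this position responds at all to a larger change, such as an unsubstituted phenyl ring, a pyridine carrying an amine or a carboxylic acid, or a longer chain in place of the single saturated chain carbon. They also leave open whether the same pyridyl exchange would stay as small with a urea linker in place of the thiourea, since only thiourea compounds carry this step.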